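The source may hold more compounds than are shown below. What is called first, only, known or untested is meant among the compounds shown, and "the series" means these compounds.

Measured in an ADME assay on HEK293 cells (Homo sapiens) for cytotoxicity, read by MTT assay, with a stated time of 48 h; on this read-out lower numbers stand for stronger inhibition and higher numbers for weaker inhibition:
- compound 1 `CCn1c(N)c(-c2nc3ccccc3[nH]2)c2nc(C#N)c(C#N)nc21`: > 50000 nM (a limit, not a number)
- compound 2 `CCCn1c(N)c(-c2nc3ccccc3[nH]2)c2nc(C#N)c(C#N)nc21`: > 50000 nM (a limit, not a number)
- compound 3 `CCN(CC)CCCn1c(N)c(-c2nc3ccccc3[nH]2)c2nc(C#N)c(C#N)nc21`: 7870 nM

Of these three, compound 3 alone gives a true number, 7870 nM. The other two stand together: the limit of > 50000 nM in this assay, at which 2 of the 3 values shown sit.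

Compound 4 `CCCCn1c(N)c(-c2nc3ccccc3[nH]2)c2nc(C#N)c(C#N)nc21` differs from compound 3 at the end of the chain: methyl in place of diethylamino on a saturated chain carbon, three bonds along the chain from an aromatic nitrogen. Put simply, 3-(diethylamino)propyl becomes butyl, with methyl in place of diethylamino.

The closest measured case is the reverse change at the same place, an at least 6.3-fold lower number from compound 2 to compound 3 (0.80 log units; beyond the scatter). A similar change, with (diethylamino)methyl entering, gave an at least 6.3-fold lower number from compound 1 to compound 3 (0.80 log units; beyond the scatter). Extending the chain with methyl alone gave a step that the two limits leave unreadable from compound 1 to compound 2, so that step offers no guide to size.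

Removing diethylamino should therefore move the number upward, towards the limit, and the expected change is a 7.6-fold higher number from compound 3 to compound 4 (0.88 log units; beyond the scatter). The assay may well report only a limit here. For compound 4 the estimated value is 60000 nM, with an expected range of 25000 nM to 150000 nM.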

Compound 4, half-maximal inhibitory concentration: > 50000 nM
Compound 4 was reported as a limit; the forecaster's own chance of this, stated with the estimate: 80%; the middle value is on the limit's open side.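

In this assay, putting methyl in place of diethylamino, on a saturated chain carbon three bonds along the chain from an aromatic nitrogen, gives an at least 6.3-fold higher number from compound 3 to compound 4 (0.80 log units; beyond the scatter). A plain butyl chain therefore does not bring the number off the limit, so among these compounds the lower number goes with the diethylamino group and not with the chain simply reaching that far. Compound 4 is reported only as a limit, and its steps to compounds 1 and 2 cannot be read: the limit of > 50000 nM in this assay, at which 3 of the 4 values shown sit.

From the compounds shown here alone, how far past the limit compounds 1, 2 and 4 lie stays open, and with it the full size of the step. Also open, going by these compounds, is whether a smaller amine such as dimethylamino, a hydroxyl or a carboxylic acid at the chain end would lower the number too.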